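The source may hold more compounds than are shown below. What is called first, only, known or untested is meant among the compounds shown, and "the series" means these compounds.

Compound 1 `CCCCCCCCc1ccc(OCC(=O)Cn2nnnc2C)cc1` gives 41 nM in an assay on microsomes from brain for inhibition of Fatty-acid amide hydrolase 1 (Rattus norvegicus), read by fluorescence and HPLC, with a stated time of 60 min; on this read-out lower numbers stand for stronger inhibition and higher numbers for weaker inhibition.
Compound 2 `CCCCCCCCc1ccc(OCC(=O)Cn2nnnc2-c2ccccc2)cc1` gives 71 nM in this assay.
Compound 3 `CCCCCCCCc1ccc(OCC(=O)Cn2nnnc2-c2ccncc2)cc1` gives 190 nM in this assay.

All three compounds share the same core and differ only in the group attached to one aromatic carbon of the five-membered ring. Compound 3 stands at the highest number of the three: the step from compound 2 is a 2.7-fold higher number from compound 2 to compound 3 (0.43 log units; beyond the scatter), and the step from compound 1 is a 4.6-fold higher number from compound 1 to compound 3 (0.67 log units; beyond the scatter).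

Compound 4 `CCCCCCCCc1ccc(OCC(=O)Cn2nnnc2Cc2ccccc2)cc1` has not been measured yet. It differs from compound 3 in one place: benzyl in place of pyridin-4-yl on an aromatic carbon.

Two measured steps speak to this change. The first, a 1.7-fold higher number from compound 1 to compound 2 (0.24 log units; within the scatter), shows that a six-membered ring of carbon only in this position gives a number close to that of methyl. The second, a 2.7-fold higher number from compound 2 to compound 3 (0.43 log units; beyond the scatter), shows that pyridin-4-yl in the same position gives a higher number than phenyl. Compound 4, like compound 2, carries a ring of carbon only, so its number is expected to fall back toward that of compound 2, a step of about a 2.9-fold lower number from compound 3 to compound 4 (0.47 log units; beyond the scatter). The estimate for compound 4 in this assay is 65 nM, with a range from 30 nM to 150 nM.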

Compound 4, half-maximal inhibitory concentration: 320 nM
The estimate for compound 4 lay 4.9-fold (0.69 log units) below the measured number; measured number above the stated range.
By their numbers in this assay, from the lowest: compounds 1 and 2 (each within the scatter of the next); then compounds 3 and 4 (each within the scatter of the next).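

A ring of carbon only does not by itself keep the number close to that of methyl in this assay: with benzyl in place of phenyl there is a 4.5-fold higher number from compound 2 to compound 4 (0.65 log units; beyond the scatter), so how the ring is joined to the aromatic carbon of the five-membered ring makes a difference here. The same holds against the small group, since phenyl in place of hydrogen on the saturated chain carbon gives a 7.8-fold higher number from compound 1 to compound 4 (0.89 log units; beyond the scatter). Within the data shown here, with benzyl in place of pyridin-4-yl there is a 1.7-fold higher number from compound 3 to compound 4 (0.23 log units; within the scatter), so two groups with different rings and different links to the aromatic carbon cannot be told apart on this read-out, and the ring nitrogen of pyridin-4-yl is not the only change at this position that goes with a number in this range.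

The data shown give no explanation for any of these steps. From the compounds shown here alone, it remains open whether the extra chain carbon alone accounts for the step from phenyl to benzyl, which ethyl could test against methyl, and whether pyridin-4-ylmethyl or 2-phenylethyl would follow benzyl.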